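Swapping the ring on the shared core: permeability expected to drop

The source may hold more compounds than are shown below. What is called first, only, known or untested is meant among the compounds shown, and "the series" means these compounds.

Measured so far:
compound 1 `Cc1ccc(NC(=O)c2cc(Oc3ccc(S(C)(=O)=O)cc3)cc(OC(C)C)c2)nc1` gives 4.4 10^-6 cm/s in an ADME assay on MDCK-II cells (Canis lupus familiaris) for permeability; a lower number here means that the compound crosses the layer more slowly, a higher number that the compound crosses the layer faster
compound 2 `CC(C)Oc1cc(Oc2ccc(S(C)(=O)=O)cc2)cc(-c2cccc(=O)[nH]2)c1` gives 18 10^-6 cm/s in this assay

Compound 2 stands highest of the two numbers; its nearest neighbour is compound 1, and the step of a 4.1-fold higher number from compound 1 to compound 2 (0.61 log units; beyond the scatter) lies beyond the scatter.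

Compound 3 `Cc1cc(=O)[nH]c(-c2cc(Oc3ccc(S(C)(=O)=O)cc3)cc(OC(C)C)c2)n1` has not yet been measured. Compared with compound 2 it carries a group of 8 heavy atoms (5 carbon, 2 nitrogen, 1 oxygen; one six-membered aromatic ring with 2 hetero atoms) in place of a group of 7 heavy atoms (5 carbon, 1 nitrogen, 1 oxygen; one six-membered aromatic ring with 1 hetero atom), on an aromatic carbon.

Within the data shown here, the only measured step, from compound 1 to compound 2, changed a different part of the molecule and went up. It bears on the new change only loosely, since the new ring brings one more acceptor to the same position. A modest fall in this assay is therefore expected for compound 3, of about a 2.0-fold lower number from compound 2 to compound 3 (0.30 log units; within the scatter), though a number within the scatter of compound 2 cannot be excluded.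

Compound 3 is estimated at 9 10^-6 cm/s, in the range 3.5 10^-6 cm/s to 22 10^-6 cm/s.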

Compound 3, apparent permeability: 4.8 10^-6 cm/s
The estimate for compound 3 lay 1.9-fold (0.27 log units) above the measured number, and the stated range covers the measured number.
By their numbers in this assay, from the lowest: compounds 1 and 3 (each within the scatter of the next); then compound 2.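

Swapping the group with one ring hetero atom for the group with two, which brings 2 hydrogen-bond acceptors in place of 1, gives a 3.8-fold lower number from compound 2 to compound 3 (0.57 log units; beyond the scatter) in this assay. This shows that the higher number of compound 2 is not shared by every ring at this position: a small change within the ring, at the same aromatic carbon of the shared core, is enough to move the read-out beyond the scatter. The step of a 1.1-fold higher number from compound 1 to compound 3 (0.04 log units; within the scatter) also puts compound 3 level with compound 1, despite their different groups, and nothing measured here accounts for these results.

As far as these compounds go, compound 3 gains both a second ring nitrogen and a methyl group on the ring, so which of the two carries the step stays open. Also open, from the compounds shown here alone, is how a ring bearing an amine, or a carboxylic acid on this aromatic carbon, would read in this assay.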